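A Bulky Group on the Sulfonyl Ring of Compound 3

A few compounds are considered here, and "the series" means these few. Any claim that something is new, unique, unknown or untested is made for them only; others in the source may bear on it.

Compound 1 `CCCN(CC[C@H]1CC[C@H](NC(=O)/C=C/c2cccc(F)c2)CC1)[C@H]1CCc2nc(N)sc2C1` gives 9.9 nM in an assay on brain for displacement of a labelled ligand from D(3) dopamine receptor (Rattus norvegicus); on this read-out higher numbers stand for weaker inhibition and lower numbers for stronger inhibition.
Compound 2 `CCCN(CC[C@H]1CC[C@H](NC(=O)/C=C/c2cccc(Cl)c2)CC1)[C@H]1CCc2nc(N)sc2C1` gives 1.2 nM in this assay.
Compound 3 `CCCN(CC[C@H]1CC[C@H](NS(=O)(=O)c2ccccc2)CC1)[C@H]1CCc2nc(N)sc2C1` gives 0.79 nM in this assay.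

Compound 3 has the lowest of the three numbers; the gap to compound 2 is within the scatter, as a 1.5-fold lower number from compound 2 to compound 3 (0.18 log units; within the scatter) shows, while a 13-fold lower number from compound 1 to compound 3 (1.10 log units; beyond the scatter) stands beyond it. Compound 4 `CCCN(CC[C@H]1CC[C@H](NS(=O)(=O)c2ccc(C(C)(C)C)cc2)CC1)[C@H]1CCc2nc(N)sc2C1` differs from compound 3 by tert-butyl in place of hydrogen on an aromatic carbon. Within the data shown here, no measured step touches this ring; the only substitution on an aromatic ring, an 8.3-fold lower number from compound 1 to compound 2 (0.92 log units; beyond the scatter), concerns a halogen swap on a different part of the molecule and gives no guide here. A step within the scatter in either direction is therefore expected, a 1.3-fold higher number from compound 3 to compound 4 (0.10 log units; within the scatter), and compound 4 is estimated at 1 nM, in the range 0.3 nM to 3.5 nM.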

Compound 4, inhibition constant: 5 nM
Beside the measured number, compound 4's estimate is 5.0-fold (0.70 log units) below it, outside the stated range (above it).
By their numbers in this assay, from the lowest: compounds 3 and 2 (each within the scatter of the next); then compounds 4 and 1 (each within the scatter of the next).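

The sulfonyl ring is not indifferent to substitution: in this assay, tert-butyl in place of hydrogen on an aromatic carbon, para to a large group, gives a 6.3-fold higher number from compound 3 to compound 4 (0.80 log units; beyond the scatter). Inhibition therefore weakens with this change, so this position tolerates a tert-butyl group less well than a hydrogen. Nothing measured here accounts for this step.

On these data alone, whether methyl, methoxy or an amine at the same carbon would cost as much remains open. So does the effect of tert-butyl on another carbon of this ring.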